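Piperidine for Pyrrolidine: Expected Tolerance of Compound 3

The compounds below may be only part of what the source reports. "The series", "measured", "known", "first", "only" and "open" are said of these compounds alone.

Compound 1 `CC1(C)[C@H]2CC[C@]1(C)[C@H](OC(=O)CN1CCCC1)C2`: 302000 nM
Compound 2 `CN1CCN(CCC(=O)O[C@@H]2C[C@@H]3CC[C@@]2(C)C3(C)C)CC1`: 48100 nM

Of the compounds shown here, two have been measured in an ADME assay on MDCK cells (Canis lupus familiaris) for cytotoxicity, read by MTT assay, with a stated time of 48 h; a lower number here means that less compound is tolerated, a higher number that more compound is tolerated. Compound 1 gives 302000 nM, the higher of the two numbers, so it is the compound of which more is tolerated. Compound 2 gives 48100 nM, and the gap between these two values lies beyond the usual scatter of this assay. Compound 2 differs from compound 1 in more than one place, so its value alone cannot tell what any single change does.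

Compound 3 `CC1(C)[C@H]2CC[C@]1(C)[C@H](OC(=O)CN1CCCCC1)C2` has not yet been measured. It differs from compound 1 in one place: piperidin-1-yl in place of pyrrolidin-1-yl on a saturated chain carbon bound to a carbonyl carbon. The amine ring grows by one carbon and stays a saturated ring with one nitrogen, still without donors and with one acceptor. Going by the values given here, no measured pair shows what this change does in this assay. With so small a change, the step is expected to stay within the scatter, leaning slightly toward a lower number. The expected step of a 1.4-fold lower number from compound 1 to compound 3 (0.14 log units; within the scatter) is therefore small. Compound 3 is estimated at 220000 nM, with a range from 90000 nM to 500000 nM.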

Compound 3, half-maximal cytotoxic concentration: 138000 nM
Compound 3: middle estimate off by 1.6-fold (0.20 log units), on the high side, and the stated range covers the measured number.
By their numbers in this assay, from the lowest: compound 2; then compound 3; then compound 1.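

Going by these compounds alone, until now, no pair of compounds differing in one place showed what the amine ring does at this saturated chain carbon bound to a carbonyl carbon. In this assay, piperidin-1-yl in place of pyrrolidin-1-yl gives a 2.2-fold lower number from compound 1 to compound 3 (0.34 log units; beyond the scatter), a modest step but one beyond the usual scatter. This shows that the result at this position is sensitive to ring size, even with the counts of hydrogen-bond donors and acceptors unchanged, although nothing available here accounts for the difference.

As far as these compounds go, a single step between two ring sizes sets no trend, so it remains open whether a seven-membered azepane ring would continue the same direction, or whether a morpholine ring or an open-chain diethylamino group would behave like either ring tested here. Compound 2 differs from compound 1 in more than one place, so it cannot show whether the same ring change would have a similar effect on a different chain or whether its lower number comes from its amine, its chain or both together.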